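This account rests on a few compounds, and the source may have more. Where it says the series, first, only, none or still open, it means among the compounds named here.

Measured in a functional assay on the whole organism with Mus musculus as the target; a higher number here means that more compound is needed for the effect, a lower number that less compound is needed:

- compound 1 `Cc1c(C)c2c(c(C)c1N)CC(C)(C)O2`: 7.8 mg/kg
- compound 2 `Cc1cc(N)c(C)c2c1OC(C)(C)C2`: 32.3 mg/kg
- compound 3 `Cc1c(C)c2c(c([N+](=O)[O-])c1N)CC(C)(C)O2`: > 100 mg/kg

Compound 3 gives no number, only a limit of the assay: the limit of > 100 mg/kg in this assay, at which 1 of the 3 values shown sits. The next compound, compound 4 `Cc1c(C)c2c(c(N(C)C)c1N)CC(C)(C)O2`, carries dimethylamino in place of nitro on an aromatic carbon.

For the measured compounds named here, two measured steps bear on this change. The closer one is an at least 12-fold higher number from compound 1 to compound 3 (1.10 log units; beyond the scatter), which puts nitro on the same aromatic carbon where compound 1 has a methyl. The other is a 4.1-fold higher number from compound 1 to compound 2 (0.62 log units; beyond the scatter), a modest step on a different aromatic carbon, and it shows that the number in this assay responds to small changes on this ring. Going by the values given here, no measured compound yet carries dimethylamino, so the size of the step is uncertain. If the large rise seen with nitro is partly undone, a modest to large move toward a lower number is expected. The expected step is an at least 3.3-fold lower number from compound 3 to compound 4 (0.52 log units; beyond the scatter), and a result at the limit remains possible. For compound 4 the estimated value is 30 mg/kg, with an expected range of 8 mg/kg to 100 mg/kg.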

Compound 4, dose for 50% inhibition: 22.3 mg/kg
Estimate against measurement, compound 4: 1.3-fold (0.13 log units) above; the range from low to high includes it.
By their numbers in this assay, from the lowest: compound 1; then compounds 4 and 2 (each within the scatter of the next). At a limit, above all of these: compound 3.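

In this assay, the position that carries methyl in compound 1 also accepts dimethylamino without the number reaching the limit, unlike nitro. Dimethylamino and nitro have the same count of heavy atoms, yet the exchange gives an at least 4.4-fold lower number from compound 3 to compound 4 (0.65 log units; beyond the scatter), a step read against a limit, so that count alone does not set the number at this position. Methyl still gives the lowest number of the three groups placed here, with a 2.9-fold higher number from compound 1 to compound 4 (0.46 log units; beyond the scatter).

As far as these compounds go, whether another amine such as pyrrolidine, or a carboxylic acid, would bring the number back toward that of compound 1 remains open. How far the true value of compound 3 lies beyond what the assay shows also remains open, and it bounds the step from nitro to dimethylamino on one side only: the limit of > 100 mg/kg in this assay, at which 1 of the 4 values shown sits.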